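The compounds below may be only part of what the source reports. "The series", "measured", "known", "first", "only" and "open" are said of these compounds alone.

The series shares one core, varied on two phenyl rings. In a functional assay on A549 cells (Homo sapiens) for antiproliferative activity, read by MTT assay, with a stated time of 48 h (a higher number here means a weaker inhibitor, a lower number a stronger inhibitor), compound 1 `O=C(/C=C\Nc1ccc(F)cc1)c1cn(-c2ccccc2)nc1-c1ccccc1` gives 4670 nM. Compound 2 `O=C(/C=C\Nc1ccc(F)cc1)c1cn(-c2ccccc2)nc1-c1ccc(F)cc1` gives 5780 nM in this assay, and compound 3 `COc1ccc(-c2nn(-c3ccccc3)cc2C(=O)/C=C\Nc2ccc(F)cc2)cc1` gives 3980 nM. Compound 3 carries the lowest number of the three, but its gaps to the others lie within the scatter: a 1.2-fold lower number from compound 1 to compound 3 (0.07 log units; within the scatter) and a 1.5-fold lower number from compound 2 to compound 3 (0.16 log units; within the scatter); likewise a 1.2-fold higher number from compound 1 to compound 2 (0.09 log units; within the scatter). The three numbers are, for practical purposes, one level.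

Compound 4 `COc1ccc(N/C=C\C(=O)c2cn(-c3ccccc3)nc2-c2ccc(OC)cc2)cc1` is not yet measured. It differs from compound 3 by methoxy in place of fluoro on an aromatic carbon. Among the compounds with values here, the single measured step with the same exchange, a 1.5-fold lower number from compound 2 to compound 3 (0.16 log units; within the scatter), sat on the other aryl ring of the core and stayed within the scatter; the fluoro-for-hydrogen and methoxy-for-hydrogen steps on that ring did the same. On that basis no step beyond the scatter is expected in this assay, with at most a slight lean toward a lower number; the expected step is a 1.1-fold lower number from compound 3 to compound 4 (0.06 log units; within the scatter). Compound 4 is accordingly estimated at 3500 nM in this assay, with a range from 1500 nM to 8500 nM.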

Compound 4, half-maximal inhibitory concentration: 6780 nM
Beside the measured number, compound 4's estimate is 1.9-fold (0.29 log units) below it, within the range that was stated.
By their numbers in this assay, from the lowest: compounds 3, 1, 2 and 4 (each within the scatter of the next).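

This is the first change shown on the (4-fluorophenyl)amino side, the other aryl ring having carried all the earlier variation. In this assay, methoxy in place of fluoro at this position gives a 1.7-fold higher number from compound 3 to compound 4 (0.23 log units; within the scatter), so the exchange stays within the scatter here as it did on the other ring, with a 1.5-fold lower number from compound 2 to compound 3 (0.16 log units; within the scatter). Compound 4 carries methoxy on both rings, and the series still reads as one level, though nothing at hand bears on why these steps are so small.

Open, going by these compounds, is whether an amine or a carboxylic acid in this place would produce a step beyond the scatter. Also open, on these data alone, is whether the same exchange at this position reads alike when the other ring carries fluoro or hydrogen.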